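A few compounds are considered here, and "the series" means these few. Any claim that something is new, unique, unknown or untested is made for them only; others in the source may bear on it.

Measured so far:
compound 1, `Nc1ncnc2c1nc(Br)n2CCCO`, with 5100 nM in a functional assay on CHO cells for antagonist activity at adenosine receptor A2b (Homo sapiens); a lower number here means a stronger inhibitor, a higher number a weaker inhibitor
compound 2, `Nc1ncnc2c1nc(Br)n2CC(O)CO`, with 7100 nM in this assay

Compound 2 and compound 1 sit within the scatter of each other in this assay, as the step of a 1.4-fold higher number from compound 1 to compound 2 (0.14 log units; within the scatter) shows. Compound 3, `C=CCCn1c(Br)nc2c(N)ncnc21`, differs from compound 2 by allyl in place of 1,2-dihydroxyethyl on a saturated chain carbon bound to an aromatic nitrogen. Within the data shown here, the only measured step that touches this part of the chain is a 1.4-fold higher number from compound 1 to compound 2 (0.14 log units; within the scatter), where a hydroxy on the chain changed little. On that basis, removing both hydroxy groups and bringing in an allyl is expected to give no step beyond the scatter in this assay, a 1.4-fold lower number from compound 2 to compound 3 (0.15 log units; within the scatter). Compound 3 is therefore estimated at 5000 nM, expected between 1500 nM and 16000 nM.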

Compound 3, inhibition constant: > 30000 nM
Compound 3 was reported as a limit (the forecaster's own chance of this, stated with the estimate: 5%); middle value at least 6.0-fold (0.77 log units) from the limit.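

Compound 3 is known in this assay only as a limit: the limit of > 30000 nM in this assay, at which 1 of the 3 values shown sits. The chain end therefore matters here, even though adding a hydroxy to the chain made no difference beyond the scatter: allyl in place of 1,2-dihydroxyethyl gives an at least 4.2-fold higher number from compound 2 to compound 3 (0.62 log units; beyond the scatter), and vinyl in place of hydroxymethyl gives an at least 5.8-fold higher number from compound 1 to compound 3 (0.76 log units; beyond the scatter). Both chains that end in a hydroxy stay measurable, while the chain ending in a double bond, with no hydroxy, does not.

From the compounds shown here alone, whether the missing hydroxy groups or the double bond matters more remains open. A saturated butyl chain, or an amine or carboxylic acid at the chain end, would help separate the two.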